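Shedding the Butyl Chain: From Compound 1 to Compound 4

The compounds below may be only part of what the source reports. "The series", "measured", "known", "first", "only" and "open" are said of these compounds alone.

Compound 1, `CCCCNC(=O)N1CC1C#N`: > 12000 nM
Compound 2, `N#CC1CN1C(=O)Nc1ccc(Cl)cc1Cl`: 900 nM
Compound 3, `N#CC1CN1C(=O)Nc1ccccc1`: 2900 nM

All three compounds were tested in a functional assay on MCF7 cells (Homo sapiens) for inhibition; on this read-out lower numbers stand for stronger inhibition and higher numbers for weaker inhibition. Compound 1 returns only a limit, > 12000 nM, and no number. This is the point described by the limit of > 12000 nM in this assay, at which 1 of the 3 values shown sits. Compound 2 gives 900 nM and compound 3 gives 2900 nM, both of them actual numbers rather than limits, with compound 2 showing the lower value of the two.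

Compound 4, `N#CC1CN1C(N)=O`, has not yet been measured. It differs from compound 1 by hydrogen in place of butyl on an amide-type nitrogen. For the measured compounds named here, no measured pair shows this change, so the size of the step cannot be read off from the data. Compound 4 is expected to stay close to compound 1, with a step that the limit leaves unreadable from compound 1 to compound 4 that is not expected to go beyond the scatter in this assay. For compound 4 the estimate is 20000 nM, within a range from 5000 nM to 80000 nM, and a limit rather than a number is the more likely outcome.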

Compound 4, half-maximal inhibitory concentration: > 54000 nM
Compound 4: no number, only a limit; the forecaster's own chance of this, stated with the estimate: 70%; at least 2.7-fold (0.43 log units) between middle value and limit.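

The step from compound 1 to compound 4 cannot be read, for both compounds return only limits and no numbers. The compounds shown leave open how far hydrogen in place of butyl on an amide-type nitrogen shifts inhibition in this assay, or whether it shifts it at all.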